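The compounds below may be only part of what the source reports. "The series", "measured", "known", "first", "only" and "open" are said of these compounds alone.

Measured in a functional assay on U-87MG ATCC cells (Homo sapiens) for antiproliferative activity, read by MTT assay, with a stated time of 48 h; on this read-out higher numbers stand for weaker inhibition and lower numbers for stronger inhibition:
- Compound 1 `COc1ccc(-c2nn(-c3ccccc3)cc2C(=O)/C=C\Nc2ccc(C(F)(F)F)cc2)cc1`: > 50000 nM, a limit
- Compound 2 `COc1ccc(-c2nn(-c3ccccc3)cc2C(=O)/C=C\Nc2ccc(O)cc2)cc1`: 3730 nM
- Compound 3 `COc1ccc(-c2nn(-c3ccccc3)cc2C(=O)/C=C\Nc2cc(OC)c(OC)c(OC)c2)cc1`: > 50000 nM, a limit

Compound 3 stands at the limit of > 50000 nM in this assay, at which 2 of the 3 values shown sit, so it has no exact number. Compound 4 `COc1cc(N/C=C\C(=O)c2cn(-c3ccccc3)nc2-c2cc(OC)c(OC)c(OC)c2)cc(OC)c1OC` carries 3,4,5-trimethoxyphenyl in place of 4-methoxyphenyl on an aromatic carbon.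

Within the data shown here, no measured step changes this place. All of them change the group on the amine nitrogen. an at least 13-fold lower number from compound 1 to compound 2 (1.12 log units; beyond the scatter) and an at least 13-fold higher number from compound 2 to compound 3 (1.12 log units; beyond the scatter) are large, while a step that the two limits leave unreadable from compound 1 to compound 3 cannot be read. They give only indirect guidance, so no clear step is expected in this assay.

The expectation rests on compound 3 with its limit of > 50000 nM. The estimated value for compound 4 is 40000 nM, with an expected range from 8000 nM to 100000 nM. The expected change is an at least 1.2-fold lower number from compound 3 to compound 4 (0.09 log units; that floor lies within the scatter).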

Compound 4, half-maximal inhibitory concentration: 5100 nM
Estimate against measurement, compound 4: 7.8-fold (0.89 log units) above, outside the stated range (below it).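

In this assay, the group on the five-membered aromatic ring turns out to matter: 3,4,5-trimethoxyphenyl in place of 4-methoxyphenyl gives an at least 9.8-fold lower number from compound 3 to compound 4 (0.99 log units; beyond the scatter). With 3,4,5-trimethoxyphenyl also on the amine nitrogen, this change turns a compound without an exact number into one with a measured number. The step has only a floor, since compound 3 stands at a limit: the limit of > 50000 nM in this assay, at which 2 of the 4 values shown sit.

On these data alone, whether the same change would help with the 4-hydroxyphenyl of compound 2 on the amine nitrogen stays open. So does the outcome with a simple methyl or an aminophenyl group at this position.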